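A few compounds are considered here, and "the series" means these few. Any claim that something is new, unique, unknown or untested is made for them only; others in the source may bear on it.

Measured so far in a functional assay on SNB-75 cells (Homo sapiens) for inhibition, read by sulforhodamine B assay, with a stated time of 48 h, tested at 0.1 uM; a lower number here means a stronger effect, a higher number a weaker effect of the compound at the concentration tested:
- compound 1, `O=C(Nc1cccc(-n2cc(-c3ccncc3)c(-c3cc(O)cc(Cl)c3)n2)c1)Nc1ccc(Cl)c(C(F)(F)F)c1`: 88%
- compound 2, `O=C(Nc1cccc(-n2cc(-c3ccncc3)c(-c3cc(O)cc(Cl)c3)n2)c1)Nc1ccc(Cl)c(Cl)c1`: 52%

Compound 1 gives the highest of the two numbers in this assay; the nearest is compound 2, with a step of a number 36 percentage points lower from compound 1 to compound 2 (beyond the scatter), which comes from chloro in place of trifluoromethyl on an aromatic carbon.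

Compound 3, `COc1cc(Cl)cc(-c2nn(-c3cccc(NC(=O)Nc4ccc(Cl)c(C(F)(F)F)c4)c3)cc2-c2ccncc2)c1`, is not yet measured. Against compound 1 it shows (methyl in place of hydrogen on an oxygen on an aromatic ring), that is hydroxy to methoxy, 3-chloro-5-hydroxyphenyl to 3-chloro-5-methoxyphenyl, on the shared core of compound 1.

Among the compounds with values here, no measured step touches this oxygen; the only step available, from compound 1 to compound 2, changes a different part of the molecule and so gives no guide to the size or direction here. With nothing to lean on, the expected step is a number 4 percentage points lower from compound 1 to compound 3 (within the scatter), none beyond the scatter, with a wide allowance either way. Compound 3 is estimated at 84%, with a range from 60% to 103%.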

Compound 3, a percentage reported as activity, at one concentration (the size of the read-out at that concentration, not a potency): 52%
Compound 3: the middle estimate sits 32 percentage points above what was measured; the measured number lies below the stated range.
By their numbers in this assay, from the lowest: compounds 2 and 3 (each within the scatter of the next); then compound 1.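

In this assay the change from hydroxy to methoxy gives a number 36 percentage points lower from compound 1 to compound 3 (beyond the scatter) and so moves the read-out towards a stronger effect at the concentration tested. The earlier pair showed a response only to chloro in place of trifluoromethyl, whereas this step shows that a second place on the shared core also responds, here to a single methyl on the oxygen. No measurement at hand accounts for this step.

The compounds shown do not tell whether the free hydrogen or the added methyl matters, and an ethoxy group, a longer alkoxy chain or an amine in place of this oxygen would help to separate the two. On these data alone, it also stays open whether the same methyl on the oxygen of compound 2 would give a step of similar size.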